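Swapping Cyclohexylmethyl for Phenoxy on the Shared Core

The source may report more compounds than this note shows. Statements on the series, on what has been measured and on what is new or still open speak of the compounds shown alone.

Of the compounds shown here, three from one study have been tested in an ADME assay on HepG2 cells (Homo sapiens) for cytotoxicity, read by luminescence, CellTiter-Glo and ATP content, with a stated time of 72 h; on this read-out lower numbers stand for an effect already at smaller amounts and higher numbers for an effect only at larger amounts of compound. Compound 1 `COc1cccc(Oc2ccc3c(NCCCNCc4cc(F)ccc4OC)ccnc3c2)c1` gives 7100 nM, compound 2 `COc1cccc(CNCCCNc2ccnc3cc(Oc4ccccc4)ccc23)c1O` gives 6800 nM, and compound 3 `COc1ccc(F)cc1CNCCCNc1ccnc2cc(CC3CCCCC3)ccc12` gives 1830 nM. Compound 3 thus has the lowest number of the three, with compound 2 its nearest neighbour, and the step of a 3.9-fold lower number from compound 1 to compound 3 (0.59 log units; beyond the scatter) shows that cyclohexylmethyl in place of 3-methoxyphenoxy lowered the number beyond the scatter.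

Compound 4 `COc1ccc(F)cc1CNCCCNc1ccnc2cc(Oc3ccccc3)ccc12` has not yet been measured in this assay. It differs from compound 3 in one place: phenoxy in place of cyclohexylmethyl on an aromatic carbon. For the measured compounds named here, the only measured step that bears on this change is the one from compound 1 to compound 3, where cyclohexylmethyl brought the lower number. Compound 4 goes the other way, back to phenoxy, and compound 2, which also carries phenoxy, sits close to compound 1 in this assay. A rise in number beyond the scatter is therefore expected, roughly undoing that step, so that compound 4 is estimated at 6000 nM, within a range of 2500 nM to 14000 nM. Such an expectation would mean a step of a 3.3-fold higher number from compound 3 to compound 4 (0.52 log units; beyond the scatter).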

Compound 4, half-maximal effective concentration: 1500 nM
For compound 4 the middle estimate is 4.0-fold (0.60 log units) above the measured one; the whole stated range lies above it.
By their numbers in this assay, from the lowest: compounds 4 and 3 (each within the scatter of the next); then compounds 2 and 1 (each within the scatter of the next).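

In this assay, exchanging cyclohexylmethyl for phenoxy on this aromatic carbon makes no difference that can be told from the scatter: the result is a 1.2-fold lower number from compound 3 to compound 4 (0.09 log units; within the scatter). The earlier drop therefore did not depend on cyclohexylmethyl, since hydrogen in place of methoxy, with the phenoxy oxygen and ring kept, already gives a 4.7-fold lower number from compound 1 to compound 4 (0.68 log units; beyond the scatter). The group on the saturated chain matters too, as 5-fluoro-2-methoxyphenyl in place of 2-hydroxy-3-methoxyphenyl gives a 4.5-fold lower number from compound 2 to compound 4 (0.66 log units; beyond the scatter).

Nothing measured here explains these steps. Still open, going by these compounds, is whether a quite different group on this aromatic carbon, such as an amine or a carboxylic acid, would leave the number unchanged, and whether a longer chain would alter the picture.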